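The source may report more compounds than this note shows. Statements on the series, on what has been measured and on what is new or still open speak of the compounds shown alone.

Notes on the series built on the shared core of compound 1 `CCN(CC)C(=O)c1ccc(NC(=O)C(C)(O)C(F)(F)F)cc1`.

In an assay on a protein complex (Cavia porcellus) with sulfonylurea receptors; K-ATP channels (Homo sapiens) as the target (on this read-out lower numbers stand for stronger inhibition and higher numbers for weaker inhibition), compound 1 gives > 30000 nM, which is a limit of the assay and not a number (the limit of > 30000 nM in this assay, at which 1 of the 3 values shown sits). Compound 2 `Cn1nnnc1-c1ccc(NC(=O)C(C)(O)C(F)(F)F)cc1` gives 30900 nM in this assay. Compound 3 `CCN(CC)S(=O)(=O)c1ccc(NC(=O)C(C)(O)C(F)(F)F)cc1` gives 810 nM in this assay. The two readable comparisons are an at least 37-fold lower number from compound 1 to compound 3 (1.56 log units; beyond the scatter) and a 38-fold lower number from compound 2 to compound 3 (1.58 log units; beyond the scatter), whereas a step that the limit leaves unreadable from compound 1 to compound 2. So far only diethylsulfamoyl has brought the number down at this position; diethylcarbamoyl and 1-methyl-1H-tetrazol-5-yl both leave it high.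

Compound 4 `CC(O)(C(=O)Nc1ccc([C@H](O)c2ccccc2)cc1)C(F)(F)F` is the next variant of compound 1: hydroxy(phenyl)methyl in place of diethylcarbamoyl on an aromatic carbon. Going by the values given here, no measured step covers hydroxy(phenyl)methyl, and the large step seen with diethylsulfamoyl is the sole example of a change at this position that moves the number beyond the scatter. With compound 1 sitting at a limit, the expected step from compound 1 is an at least 3.7-fold lower number from compound 1 to compound 4 (0.57 log units; beyond the scatter), a modest lowering at best and possibly none readable. The estimate for compound 4 in this assay is 8000 nM, within a range of 1000 nM to 40000 nM.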

Compound 4, half-maximal inhibitory concentration: > 30000 nM
Compound 4: a limit, no number; the forecaster's own chance of this, stated with the estimate: 35%; middle value at least 3.7-fold (0.57 log units) from the limit.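

In this assay compound 4 gives > 30000 nM, which is a limit of the assay and not a number. Going by these compounds alone, replacing diethylsulfamoyl with hydroxy(phenyl)methyl gives an at least 37-fold higher number from compound 3 to compound 4 (1.56 log units; beyond the scatter), so a group that brings in a six-membered aromatic ring of carbon only and a hydrogen-bond donor does not restore the low number, and diethylsulfamoyl remains the only group at this position to give one. The steps to compound 4 from compound 1 and from compound 2 cannot be read, and the limit now holds a larger share of the series: the limit of > 30000 nM in this assay, at which 2 of the 4 values shown sit.

From the compounds shown here alone, it remains open whether the low number of compound 3 depends on the sulfonyl link or on its two ethyl groups, which a dimethylsulfamoyl or piperidine-1-sulfonyl group would separate. The compounds shown also leave open how a benzoyl group or the opposite stereocentre of hydroxy(phenyl)methyl would behave here.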